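Shortening one side chain: the stability of compound 3

This account rests on a few compounds, and the source may have more. Where it says the series, first, only, none or still open, it means among the compounds named here.

In a physicochemical assay, read by HPLC, in phosphate buffer, with a stated time of 24 h, at pH 7.4 (on this read-out lower numbers stand for a less stable compound and higher numbers for a more stable compound), compound 1 `CCCCCc1ccc(-c2cc3cn([C@H]4C[C@H](OC(=O)[C@@H](NC(=O)[C@@H]5CCCN5C(=O)[C@@H](N)C(C)C)C(C)C)[C@@H](CO)O4)c(=O)nc3o2)cc1` reads > 95% as a limit of the assay and not a number. Among the compounds with values here, compound 2 `CCCCCc1ccc(-c2cc3cn([C@H]4C[C@H](O)[C@@H](COC(=O)[C@H](CC(C)C)NC(=O)[C@@H]5CCCN5C(=O)[C@@H](N)C(C)C)O4)c(=O)nc3o2)cc1` gives 69% in this assay and so holds the only actual number available. Compound 3 `CCCCCc1ccc(-c2cc3cn([C@H]4C[C@H](O)[C@@H](COC(=O)[C@H](C)NC(=O)[C@@H]5CCCN5C(=O)[C@@H](N)C(C)C)O4)c(=O)nc3o2)cc1` differs from compound 2 through hydrogen in place of isopropyl on a saturated chain carbon, two bonds along the chain from an amide-type nitrogen and a carbonyl carbon with hydrogen in place of isopropyl on a saturated chain carbon, two bonds along the chain from an amide-type nitrogen and a carbonyl carbon. A fall beyond the scatter is expected in this assay for this change, and a number 19 percentage points lower from compound 2 to compound 3 (beyond the scatter) is the estimated step. The estimated value for compound 3 is 50% and the expected range runs from 30% to 68% in this estimate.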

Compound 3, percent of the compound remaining: 74%
Compound 3: the middle estimate sits 24 percentage points below what was measured; measured number outside the range, above it.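

Read in this assay, hydrogen in place of isopropyl on a saturated chain carbon, two bonds along the chain from an amide-type nitrogen and a carbonyl carbon gives a number 5 percentage points higher from compound 2 to compound 3 (within the scatter). This first step at this position shows that the isobutyl and methyl forms of the chain cannot be told apart on this read-out. Compound 1 reads at a limit of the assay and not a number, so it offers no step here: the limit of > 95% in this assay, at which 1 of the 3 values shown sits.

Going by these compounds, whether an amine, a carboxylic acid or a longer chain at this place would read the same remains open. So does whether this change would read alike in the setting of compound 1.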